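The source may report more compounds than this note shows. Statements on the series, on what has been measured and on what is new or still open speak of the compounds shown alone.

Of the compounds shown here, two built on one shared core have been measured in an assay on L1.2 cells for binding affinity to C-C chemokine receptor type 8 (Homo sapiens); a higher number here means a weaker inhibitor, a lower number a stronger inhibitor. Compound 1 `CCC(=O)N1CCC(NS(=O)(=O)c2ccc(NC(=O)c3ccccc3C)c3ccccc23)CC1` gives 2.5 nM. Compound 2 `Cc1ccccc1C(=O)Nc1ccc(S(=O)(=O)NC2CCN(C(=O)CCCCN)CC2)c2ccccc12` gives 199 nM, the higher of the two numbers, which makes it the weaker binder of the pair. Within the data shown here, the only measured step, an 80-fold higher number from compound 1 to compound 2 (1.90 log units; beyond the scatter), came from putting a 2-aminoethyl in place of hydrogen on a saturated chain carbon, two bonds along the chain from a carbonyl carbon. Compound 3 `Cc1ccccc1C(=O)Nc1ccc(S(=O)(=O)NC2CCN(C(N)=O)CC2)c2ccccc12` has not yet been measured and differs from compound 2 in one place: amino in place of 4-aminobutyl on a carbonyl carbon. This change removes the whole chain whose lengthening drove that large loss and leaves only a small amino on the carbonyl carbon, so compound 3 is expected to move back toward compound 1, a step of a 17-fold lower number from compound 2 to compound 3 (1.22 log units; beyond the scatter) in this assay. The estimate for compound 3 is 12 nM, expected to fall between 2.5 nM and 60 nM.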

Compound 3, inhibition constant: 243 nM
Compound 3: the middle estimate sits 20-fold (1.31 log units) below what was measured, outside the stated range (above it).
By their numbers in this assay, from the lowest: compound 1; then compounds 2 and 3 (each within the scatter of the next).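

In this assay, amino in place of 4-aminobutyl on a carbonyl carbon gives a 1.2-fold higher number from compound 2 to compound 3 (0.09 log units; within the scatter), so cutting the group from 5 heavy atoms to 1 does not separate these two compounds. Amino in place of ethyl at the same carbon gives a 97-fold higher number from compound 1 to compound 3 (1.99 log units; beyond the scatter), which shows that a small group alone does not restore the strong binding of compound 1, and that the identity of the group matters here, not just its length. Nothing shown explains why 4-aminobutyl and amino read alike.

As far as these compounds go, it remains open whether a methyl or a propyl on this carbonyl carbon would stay close to ethyl. A plain butyl would help show whether the long chain or its terminal amine goes with the weaker binding of compound 2.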